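This account rests on a few compounds, and the source may have more. Where it says the series, first, only, none or still open, it means among the compounds named here.

Working notes on the series.

Of the compounds shown here, three have been measured in a functional assay on the whole organism (Abdomen, strain Swiss albino) with Mus musculus as the target, with stated times of 10 min and 5 min, at a dose of 30 mg/kg by the oral route; a lower number here means a weaker effect, a higher number a stronger effect of the compound at the dose given. Compound 1 `CCOc1ccc(-c2nn(-c3ccccc3)cc2C2=NOC3C(=O)N(C)C(=O)C23)cc1` gives 47.5% there. Compound 2 `O=C1C2ON=C(c3cn(-c4ccccc4)nc3-c3ccc(Cl)cc3)C2C(=O)N1c1ccccc1` gives 43.2%. Compound 3 `CN1C(=O)C2ON=C(c3cn(-c4ccccc4)nc3-c3ccc(Cl)cc3)C2C1=O` gives 23.2%, the lowest of the three numbers, and both of its steps from the others lie beyond the scatter: a number 24.3 percentage points lower from compound 1 to compound 3 (beyond the scatter), and a number 20 percentage points lower from compound 2 to compound 3 (beyond the scatter). Compound 3 thus combines the chloro-bearing aryl of compound 2 with the methyl on the ring nitrogen of compound 1 and sits clearly under both.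

The next compound, compound 4 `Cc1ccc(N2C(=O)C3ON=C(c4cn(-c5ccccc5)nc4-c4ccc(Cl)cc4)C3C2=O)cc1`, differs from compound 3 in one place: 4-methylphenyl in place of methyl on an amide-type nitrogen in a ring. Among the compounds with values here, the step that bears on this is the one between compound 2 and compound 3, which was measured at the same nitrogen with phenyl against methyl, and it ran to a number 20 percentage points lower from compound 2 to compound 3 (beyond the scatter). Within the data shown here, compound 4 reverses that direction with a 4-methylphenyl instead of a phenyl; no measured pair shows what the added methyl on the aryl ring does, so its contribution is unknown. The expectation is therefore a step up of roughly the size seen from compound 2 to compound 3, that is a number 19.8 percentage points higher from compound 3 to compound 4 (beyond the scatter), carrying compound 4 back close to the level of compound 2 at 43.2%.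

Compound 4 is accordingly estimated at 43%, with a range from 28% to 58%.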

Compound 4, a percentage reported as activity, at one dose (the size of the read-out at that dose, not a potency): 42.8%
For compound 4 the middle estimate is 0.2 percentage points above the measured one, and the stated range covers the measured number.
By their numbers in this assay, from the lowest: compound 3; then compounds 4, 2 and 1 (each within the scatter of the next).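

In this assay, the amide-type nitrogen in a ring now has a second aryl group to set against methyl: there is a number 19.6 percentage points higher from compound 3 to compound 4 (beyond the scatter), in the same direction as the phenyl of compound 2 against the methyl of compound 3, so among these three compounds both aryl groups read above methyl. The methyl on the aromatic ring, the open point before this result, gives a number 0.4 percentage points lower from compound 2 to compound 4 (within the scatter), so at this dose methyl in place of hydrogen on an aromatic carbon cannot be told apart from no change. Nothing in hand speaks to why an aryl group and a methyl on this nitrogen read differently.

Of the groups on this nitrogen, the compounds shown cover only methyl, phenyl and 4-methylphenyl, so it stays open whether a benzyl group, a longer alkyl chain, or a phenyl carrying an amine or a carboxylic acid would hold the level of compound 2 and compound 4. Also open is how the ethoxy of compound 1 would read with an aryl group on this nitrogen, as the step from ethoxy to chloro is shown only with methyl there.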